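Nitro to amino swap on the styryl benzylsulfone series

The source may hold more compounds than are shown below. What is called first, only, known or untested is meant among the compounds shown, and "the series" means these compounds.

Measured so far:
compound 1 `COc1cc(OC)c(/C=C/S(=O)(=O)Cc2ccc(OC)c([N+](=O)[O-])c2)c(OC)c1` — 880 nM
compound 2 `COc1ccc(CS(=O)(=O)CC(=O)Nc2c(C)cc(C)cc2C)cc1N` — > 30000 nM

For the measured compounds named here, compound 1 is the only compound of the set with a numerical read-out in a functional assay on MCF7 cells (Homo sapiens) for cytotoxicity, read by MTT assay, with a stated time of 72 h (a lower number here means a stronger inhibitor of growth, a higher number a weaker inhibitor of growth), where compound 1 gives 880 nM. Compound 2, which carries a different core and an amide linker, reaches only (the limit of > 30000 nM in this assay, at which 1 of the 2 values shown sits); this is a limit of the assay, not a measured number, so compound 2 places no bound on what the change below may do. Going by the values given here, no step between two measured compounds is available, so the pair compound 1 and compound 3 is read from the structures alone.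

Compound 3 `COc1cc(OC)c(/C=C/S(=O)(=O)Cc2ccc(OC)c(N)c2)c(OC)c1` is the unmeasured analogue. It differs from compound 1 as follows: amino in place of nitro on an aromatic carbon. The amino group takes the position ortho to a methoxy group, meta to a large group, on the same core.

Without a measured step of this kind, the expected step of a 2.2-fold lower number from compound 1 to compound 3 (0.34 log units; beyond the scatter) is modest and toward stronger inhibition, but could equally fall within the scatter. Compound 3 is estimated at 400 nM, with a range from 100 nM to 3000 nM.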

Compound 3, concentration for 50% growth inhibition: < 10 nM
Compound 3 ended at the assay's limit; the forecaster's own chance of this, stated with the estimate: 8%; middle value at least 40-fold (1.60 log units) from the limit.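

In this assay, the place ortho to a methoxy group, meta to a large group, proves highly sensitive to this one change: amino in place of nitro gives an at least 88-fold lower number from compound 1 to compound 3 (1.94 log units; beyond the scatter), a large step on an otherwise unchanged core. The reading for compound 3 is a limit of the assay and not a number, so the step gives only the smallest size the change can have: the limit of < 10 nM in this assay, at which 1 of the 3 values shown sits. For the compounds shown here, compound 2 also carries the amino group, but it has a different core and an amide linker, so it could not show what this change does on its own, and only this pair isolates it.

On these data alone, whether the effect belongs to the amino group itself or would also appear with a hydroxyl, an acetamide or a dimethylamino group at this place remains open. Also open, as far as these compounds go, are how far compound 3 lies past its limit and whether the same swap would give a step of this size on the core of compound 2.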